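The source may hold more compounds than are shown below. What is called first, only, known or untested is meant among the compounds shown, and "the series" means these compounds.

Working notes on a small series sharing one core, read in a functional assay on HCT-116 cells (Homo sapiens) for inhibition, read by colorimetric assay, with a stated time of 3 days; on this read-out higher numbers stand for weaker inhibition and lower numbers for stronger inhibition. Compound 1 (`COc1ccc(OC)c(NC(=O)CCCCCCNC(=O)C(O)(O)C(F)(F)F)c1`) gives 3870 nM. Compound 2 (`O=C(CCCCCCNC(=O)C(O)(O)C(F)(F)F)Nc1ccccc1Br`) gives 14500 nM, the higher of the two numbers available, and its gap down to compound 1 lies beyond the scatter. Compound 3 (`O=C(CCCCCCNC(=O)C(O)C(F)(F)F)Nc1nccs1`) is reported only as > 40000 nM, which is a limit of this assay and not a number.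

Compound 4 (`O=C(CCCCCCNC(=O)C(O)(O)C(F)(F)F)Nc1ccc(Br)cc1`) has not yet been measured. It has the same atoms as compound 2, joined differently: 4-bromophenyl in place of 2-bromophenyl on an amide-type nitrogen. In words, 4-bromophenyl stands in place of 2-bromophenyl on an amide-type nitrogen.

Among the compounds with values here, no measured pair differs in one place only, so the size of this step has no direct precedent. Within the data shown here, the only guide is the spread between compound 1 at 3870 nM and compound 2 at 14500 nM. A small move toward a lower number, meaning stronger inhibition, is expected, and it should not exceed that spread. The estimated 2.1-fold lower number from compound 2 to compound 4 (0.32 log units; beyond the scatter) sits close to the edge of the scatter. For compound 4 the expected value is 7000 nM, with an estimated range of 2500 nM to 20000 nM.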

Compound 4, half-maximal inhibitory concentration: 3130 nM
The estimate for compound 4 lay 2.2-fold (0.35 log units) above the measured number; the range from low to high includes it.
By their numbers in this assay, from the lowest: compounds 4 and 1 (each within the scatter of the next); then compound 2. At a limit, above all of these: compound 3.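

In this assay, within the data shown here, putting 4-bromophenyl in place of 2-bromophenyl on an amide-type nitrogen gives a 4.6-fold lower number from compound 2 to compound 4 (0.67 log units; beyond the scatter) and is the first change that can be read at a single place. The group that leaves and the group that enters have the same heavy atoms, the same ring and the same counts of donors and acceptors, with no net charge on either, so the number at this place depends on how the bromine is joined and not only on which atoms are present. The compounds shown hold no measurement that bears on the reason for this step.

From the compounds shown here alone, whether a step of this size also appears with chlorine or an amine in place of the bromine remains open, since a single pair of bromine isomers cannot show whether the result extends to other groups on the phenyl ring. Also open, going by these compounds, is whether the step keeps its size with a longer chain between the two amide groups of the shared core.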